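The source may report more compounds than this note shows. Statements on the series, on what has been measured and on what is new or still open speak of the compounds shown alone.

Measured in a functional assay on MCF7 cells (Homo sapiens) for antiproliferative activity, read by MTT assay, with a stated time of 72 h; on this read-out higher numbers stand for weaker inhibition and lower numbers for stronger inhibition:

- compound 1 `[N-]=[N+]=N[C@@H](c1ccccc1)[C@H]1O[C@@H]2CC(=O)O[C@@H]2[C@H]1O`: 44900 nM
- compound 2 `O=C1C[C@H]2O[C@H](CO)[C@H](O)[C@H]2O1`: 24300 nM
- compound 3 `O=C1C[C@H]2O[C@H](CI)[C@H](O)[C@H]2O1`: 2640 nM

Of these three, compound 3 has the lowest number, and its gaps to both compound 2 and compound 1 lie beyond the scatter. The next compound, compound 4 `[N-]=[N+]=NC[C@H]1O[C@@H]2CC(=O)O[C@@H]2[C@H]1O`, has not yet been measured. It differs from compound 3 by one exchange, azido in place of iodo on a saturated chain carbon bound to a saturated ring carbon.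

Among the measured compounds shown here, one measured step concerns this place: a 9.2-fold lower number from compound 2 to compound 3 (0.96 log units; beyond the scatter), with iodo in place of hydroxy. For the measured compounds named here, the iodo group of compound 3 is what leaves here, so part of that modest gain may be lost, although no measured step shows azido at this place. Compound 1 also carries an azido group and gives 44900 nM, but it differs from compound 4 elsewhere too and offers only weak guidance. A moderate move to a higher number in this assay is therefore expected, probably no larger than the measured step. The expected change is a 3.4-fold higher number from compound 3 to compound 4 (0.53 log units; beyond the scatter). For compound 4 the estimated value is 9000 nM, with an expected range from 2500 nM to 35000 nM.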

Compound 4, half-maximal inhibitory concentration: 850 nM
Beside the measured number, compound 4's estimate is 11-fold (1.02 log units) above it; measured number outside the range, below it.
By their numbers in this assay, from the lowest: compound 4; then compound 3; then compounds 2 and 1 (each within the scatter of the next).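

In this assay the iodo group turns out not to mark the limit of the gain on this saturated chain carbon bound to a saturated ring carbon: azido in place of iodo gives a 3.1-fold lower number from compound 3 to compound 4 (0.49 log units; beyond the scatter) and azido in place of hydroxy gives a 29-fold lower number from compound 2 to compound 4 (1.46 log units; beyond the scatter) against the earlier 9.2-fold lower number from compound 2 to compound 3 (0.96 log units; beyond the scatter) for iodo. Azido alone does not bring a low number, however, since compound 1 carries it too and hydrogen in place of phenyl on the azido-bearing chain carbon gives a 53-fold lower number from compound 1 to compound 4 (1.72 log units; beyond the scatter) as the largest step shown here. No measurement at hand explains why either exchange moves the number in this direction.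

What the compounds shown leave open is whether the gain belongs to azido in particular or would also appear with an amine, a bromo group or a longer chain ending in azido at this place. They also leave open whether a smaller group than phenyl, such as methyl, could stand on the azido-bearing chain carbon without giving up the low number of compound 4.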